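Working notes on terminal aryl substituent change, compound 3

The source may report more compounds than this note shows. Statements on the series, on what has been measured and on what is new or still open speak of the compounds shown alone.

Measured so far:
compound 1 `CC[C@H](C)[C@H](N)CN(C(=O)[C@@H]1C[C@H]1c1ccccc1)c1ccc(-c2ccc(C(F)(F)F)cc2)cc1` — 340 nM
compound 2 `CC[C@H](C)[C@H](N)CN(C(=O)[C@@H]1C[C@H]1c1ccccc1)c1ccc(-c2ccc(C(=O)N(C)C)cc2)cc1` — 980 nM

Both compounds were measured in a functional assay for agonist activity at G protein-coupled receptor 88 (Homo sapiens), read by HTRF and cAMP accumulation; a lower number here means that less compound is needed, a higher number that more compound is needed for the effect. Going by the values given here, compound 2 carries the highest of the two numbers; its nearest neighbour is compound 1, and the only measured step is a 2.9-fold higher number from compound 1 to compound 2 (0.46 log units; beyond the scatter), a modest move beyond the scatter.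

Compound 3 `CC[C@H](C)[C@H](N)CN(C(=O)[C@@H]1C[C@H]1c1ccccc1)c1ccc(-c2ccc(N)cc2)cc1` is not yet measured. It differs from compound 2 by amino in place of dimethylcarbamoyl on an aromatic carbon. Among the compounds with values here, the one step that bears on it is a 2.9-fold higher number from compound 1 to compound 2 (0.46 log units; beyond the scatter): the same aromatic carbon, exchanged between two groups, moved the number modestly. Within the data shown here, no measured step covers the amino group itself, so direction is open. A small step is expected, a 1.5-fold higher number from compound 2 to compound 3 (0.18 log units; within the scatter), with a wide range on either side. For compound 3 in this assay the estimate is 1500 nM, expected between 400 nM and 6000 nM.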

Compound 3, half-maximal effective concentration: 320 nM
Compound 3: middle estimate off by 4.7-fold (0.67 log units), on the high side; the whole stated range lies above it.
By their numbers in this assay, from the lowest: compounds 3 and 1 (each within the scatter of the next); then compound 2.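

In this assay, going by these compounds alone, replacing dimethylcarbamoyl with amino gives a 3.1-fold lower number from compound 2 to compound 3 (0.49 log units; beyond the scatter), so the position also shows a step toward a lower number, not only the step seen earlier toward a higher one. Amino in place of trifluoromethyl gives a 1.1-fold lower number from compound 1 to compound 3 (0.03 log units; within the scatter), so these two groups cannot be told apart here, while dimethylcarbamoyl stands apart from both. No measurement available here accounts for this pattern.

As far as these compounds go, it remains open whether a carboxylic acid, a nitrile or a methylamino group at the same carbon would fall with amino and trifluoromethyl or with dimethylcarbamoyl. A primary carboxamide would show whether the separation of compound 2 follows the carbonyl unit or its methyl groups.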